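The source may report more compounds than this note shows. Statements on the series, on what has been measured and on what is new or still open speak of the compounds shown alone.

Measured so far:

Compound 1 `C/C(=C\c1cc(-c2cccnc2)co1)C(N)=O` — in a functional assay on HeLa cells (Homo sapiens) for cytotoxicity, read by CCK-8 assay, with a stated time of 24 h (on this read-out lower numbers stand for stronger inhibition and higher numbers for weaker inhibition), compound 1 is reported only as a limit, > 50000 nM.
Compound 2 `C/C(=C\c1cc(-c2ccc(C)nc2)co1)C(N)=O` — in this assay compound 2 likewise returns only a limit, > 50000 nM.
Compound 3 `C/C(=C\c1nc(-c2ccccc2)cs1)C(N)=O` — in this assay compound 3 gives 2770 nM.

Going by the values given here, the one change seen twice is methyl in place of hydrogen on an aromatic carbon. Between compound 1 and compound 2 its effect is a step that the two limits leave unreadable from compound 1 to compound 2, and no more can be said of it, since (the limit of > 50000 nM in this assay, at which 2 of the 3 values shown sit).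

Compound 4 `C/C(=C\c1nc(-c2ccc(C)cc2)cs1)C(N)=O` has not been measured. It relates to compound 3 by methyl in place of hydrogen on an aromatic carbon. This is the same kind of change as that from compound 1 to compound 2, not the same: there the methyl enters on a six-membered aromatic ring with 1 nitrogen, next to the ring nitrogen; here it enters on a six-membered aromatic ring of carbon only. Among the compounds with values here, how the core of compound 3 differs from the core of compound 1 is not broken down here; compound 3 simply carries the only real number in this assay.

For compound 4 the step from compound 3 is expected to be small, a 1.1-fold higher number from compound 3 to compound 4 (0.03 log units; within the scatter), resting on the observation that compound 3 already gives 2770 nM and that the measured pair gives no readable size for a methyl step. Compound 4 is therefore estimated at 3000 nM, between 1000 nM and 10000 nM.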

Compound 4, half-maximal inhibitory concentration: 25000 nM
Compound 4: middle estimate off by 8.3-fold (0.92 log units), on the low side; the measured number lies above the stated range.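

In this assay the change of methyl in place of hydrogen, on an aromatic carbon of a six-membered aromatic ring of carbon only and para to a large group, gives a 9.0-fold higher number from compound 3 to compound 4 (0.96 log units; beyond the scatter) and so has a measurable size on the core of compound 3. That single readable step does not show how the change carries from one core to another, and the step from compound 1 to compound 2 cannot be read, so no size on the core of compound 1 can be set against it, because the values there are limits: (the limit of > 50000 nM in this assay, at which 2 of the 4 values shown sit). The two methyl changes also differ in the ring that receives the group, so even a readable second step would not separate the effect of that ring from the effect of the rest of the core.

From the compounds shown here alone, it stays open whether the number in this assay keeps rising with a longer chain such as ethyl or propyl at this place, or moves the other way with an amine or a carboxylic acid there. Also open, going by these compounds, is whether the core of compound 1 would give a real number with a six-membered aromatic ring of carbon only in place of its ring with nitrogen.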